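This account rests on a few compounds, and the source may have more. Where it says the series, first, only, none or still open, it means among the compounds named here.

Measured in a functional assay on the whole organism (strain albino) for inhibition, with Rattus norvegicus as the target, read by paw edema, with stated times of 30 min and 4 h, at a dose of 25 mg/kg by the intraperitoneal route; a lower number here means less inhibition, a higher number more inhibition at the dose given (going by the name of the read-out):

Compound 1, `CCOC(=O)c1nn(-c2ccccc2)c(-c2ccc(OC)cc2OC)c1-c1ccccc1`, gives 20.2%.
Compound 2, `CCOC(=O)c1nn(-c2ccccc2)c(-c2ccc(OC)cc2OC)c1C`, gives 5.77%.
Compound 3, `COc1ccc(-c2c(C)c(C(=O)O)nn2-c2ccc(Cl)cc2)c(OC)c1`, gives 22.7%.

Of the compounds shown here, three built on one core have been tested in this assay. Compound 1 and compound 2 share the same ester and the same phenyl on the ring nitrogen and differ in a single spot, (phenyl in place of methyl on an aromatic carbon). That change produced a number 14.4 percentage points higher from compound 2 to compound 1 (beyond the scatter). Compound 3 carries a different set of groups, and the difference between the core of compound 3 and the core of compound 2 is not broken down here; their two values show compound 3 reading higher than compound 2 by a margin that lies beyond the scatter. Compound 3 and compound 1, by contrast, lie within the scatter of each other, so no order between them can be claimed.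

Compound 4, `COc1ccc(-c2c(-c3ccccc3)c(C(=O)O)nn2-c2ccc(Cl)cc2)c(OC)c1`, has not yet been measured. It relates to compound 3 by phenyl in place of methyl on an aromatic carbon. For the measured compounds named here, this is the same kind of change as the one from compound 2 to compound 1, though the surroundings are not the same: in compound 4 the place is next to the ring atom that bears a carboxy group and two ring bonds from the ring atom that bears a 4-chlorophenyl group, where in compound 1 it is next to the ring atom that bears an ethoxycarbonyl group and two ring bonds from the ring atom that bears a phenyl group. Going by the values given here, with only one earlier instance to rest on, the expected step is a number 10.3 percentage points higher from compound 3 to compound 4 (beyond the scatter), somewhat smaller than the one observed, because a number 14.4 percentage points higher from compound 2 to compound 1 (beyond the scatter) may not carry over fully. Compound 4 is therefore estimated at 33% in this assay, with a plausible range from 18% to 48%.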

Compound 4, a percentage reported as inhibition, in the whole organism at one dose (the size of the read-out at that dose, not a potency): 42.5%
Beside the measured number, compound 4's estimate is 9.5 percentage points below it; low and high end bracket the measured number.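

In this assay, phenyl in place of methyl on an aromatic carbon of the core of compound 3 gave a number 19.8 percentage points higher from compound 3 to compound 4 (beyond the scatter), so the reading rose on this core as well. For the compounds shown here, the two instances of the change point the same way, and no difference in size between them can be claimed: the same change on two cores in this assay, a number 14.4 percentage points higher (beyond the scatter) from compound 2 to compound 1 and a number 19.8 percentage points higher (beyond the scatter) from compound 3 to compound 4, 5.4 percentage points apart, within the scatter of two such steps This shows that the change carried over from a core with an ethoxycarbonyl group and a phenyl group to one with a carboxy group and a 4-chlorophenyl group, but it rests on only two pairs, read at a single dose, and it neither explains the rise nor shows that the step would hold on any other core.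

Among the compounds shown, only methyl and phenyl stand at this place, which leaves open how a longer chain such as propyl, or a benzyl group, would read there. Going by these compounds alone, whether an amide would read differently from the carboxy group or the ethoxycarbonyl group also stays open, and no pair here differs in that group alone, so the contribution of that part of the molecule cannot be read.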